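The source may hold more compounds than are shown below. What is called first, only, known or untested is meant among the compounds shown, and "the series" means these compounds.

Measured so far:
compound 1 `Cc1cc(NC(=O)Nc2cccc([N+](=O)[O-])c2)c2ccccc2n1` – > 25000 nM
compound 2 `Cc1cc(NC(=O)Nc2ccc([N+](=O)[O-])c(C(F)(F)F)c2)c2ccccc2n1` – > 25000 nM

Both measured compounds carry a nitro group and both come out at the top of the measurable window of an ADME assay on BJ cells (Homo sapiens) for cytotoxicity, with a stated time of 72 h; on this read-out higher numbers stand for an effect only at larger amounts of compound and lower numbers for an effect already at smaller amounts. The value of compound 1 is a limit of this assay and not a number. The value of compound 2 is likewise a limit. Among the compounds with values here, with two limits there is no order between the pair and no step can be computed; the only evidence is the limit of > 25000 nM in this assay, at which 2 of the 2 values shown sit, which places every value shown at the same ceiling. Compound 1 therefore stands exactly where compound 2 does, at the limit, with nothing to separate them.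

Compound 3 `Cc1cc(NC(=O)Nc2cccc(Cl)c2)c2ccccc2n1` has not been measured. It differs from compound 1 by chloro in place of nitro on an aromatic carbon. Within the data shown here, since both known values are limits and no measured step exists, in this assay no step beyond the scatter is expected in either direction, and compound 3 is expected most likely to return a limit again rather than a number. Compound 3 is estimated at 30000 nM, within a range of 10000 nM to 100000 nM. The expected step is a step that the limit leaves unreadable from compound 1 to compound 3.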

Compound 3, half-maximal effective concentration: > 25000 nM
Compound 3: no number, only a limit (the forecaster's own chance of this, stated with the estimate: 80%); the middle value is on the limit's open side.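

In this assay no new step can be read between compound 1 and compound 3, since neither value is a number and both are limits: the limit of > 25000 nM in this assay, at which 3 of the 3 values shown sit.

The compounds shown leave open how far any of them lies past that limit, and whether any change on the shared core gives a measurable value in this assay.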